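The source may hold more compounds than are shown below. What is called first, only, known or untested is meant among the compounds shown, and "the series" means these compounds.

Compound 1: `CC(C)CNc1nc(N)nc2c1ncn2/C=C1/CC1(CO)CO`, "not determined" (no result reported) in an ADME assay on MOLT-3 cells (Homo sapiens) for cytotoxicity, with a stated time of 7 days; on this read-out lower numbers stand for higher toxicity in this test and higher numbers for lower toxicity in this test.
Compound 2: `Nc1nc(N2CCCC2)c2ncn(/C=C3/CC3(CO)CO)c2n1`, "not determined" (no result reported).
Compound 3: `CCCCCCCCSc1nc(N)nc2c1ncn2/C=C1/CC1(CO)CO`, > 20000 nM.

Three compounds share one core and were tested in this assay. For compound 1 no single number was recorded, and the same holds for compound 2. Compound 3 is the only one with a reported result, and that result is a limit of the assay rather than a number: compound 3 gives > 20000 nM, which means that no toxic effect was reached within the tested range. This is the limit of > 20000 nM in this assay, at which 1 of the 3 values shown sits, and among the three values shown one sits at it. Compound 1 therefore stands without any number of its own, with one neighbour at a limit and one neighbour without a result.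

The step from compound 1 to compound 4 (`CCOc1nc(N)nc2c1ncn2/C=C1/CC1(CO)CO`) changes a single group on the core: ethoxy in place of isobutylamino on an aromatic carbon. Within the data shown here, no measured step of this kind exists to guide the expectation. Given the one limit in this assay, compound 4 is expected to show little toxicity as well, with an estimated value of 20000 nM, expected to fall between 5000 nM and 60000 nM.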

Compound 4, half-maximal cytotoxic concentration: > 20000 nM
Compound 4: no number, only a limit; the forecaster's own chance of this, stated with the estimate: 70%; the middle value lies on the limit itself.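

Among these compounds, compound 3 and compound 4 both sit at a limit of this assay rather than at a number, so no step between them can be read: the limit of > 20000 nM in this assay, at which 2 of the 4 values shown sit.

The compounds shown leave open whether any group at this place on the shared core produces a measurable toxic effect.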